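The compounds below may be only part of what the source reports. "The series", "measured", "known", "first", "only" and "open" are said of these compounds alone.

In a functional assay on A549 cells (Homo sapiens) for inhibition, read by sulforhodamine B assay, with a stated time of 48 h (on this read-out higher numbers stand for weaker inhibition of growth and lower numbers for stronger inhibition of growth), the measured compounds stand as follows:
- compound 1 `COc1ccc(OC)c(C=C(C(=O)/C=C/c2ccc(O)c(OC)c2)C(=O)/C=C/c2ccc(O)c(OC)c2)c1` gives 670 nM
- compound 2 `COc1ccc(C=C(C(=O)/C=C/c2ccc(OC)c(OC)c2)C(=O)/C=C/c2ccc(OC)c(OC)c2)c(OC)c1` gives 650 nM

Compound 1 and compound 2 lie within the scatter of each other, so compound 1 holds no separate place on these numbers. Compound 3 `COc1ccc(C=C(C(=O)/C=C/c2ccc(O)c(OC)c2)C(=O)/C=C/c2ccc(O)c(OC)c2)c(OC)c1` differs from compound 1 by a single change (2,4-dimethoxyphenyl in place of 2,5-dimethoxyphenyl on a double-bonded chain carbon bound to a double-bonded chain carbon), with 2,4-dimethoxyphenyl in place of 2,5-dimethoxyphenyl on a double-bonded chain carbon bound to a double-bonded chain carbon. Within the data shown here, no measured pair shows this change, so in this assay no shift beyond the scatter is expected. The expected step of a 1.1-fold lower number from compound 1 to compound 3 (0.03 log units; within the scatter) is therefore small and has no firm direction. The estimate for compound 3 is 620 nM with an expected range from 260 nM to 1500 nM at the upper end.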

Compound 3, concentration for 50% growth inhibition: 690 nM
The estimate for compound 3 lay 1.1-fold (0.05 log units) below the measured number; low and high end bracket the measured number.
By their numbers in this assay, from the lowest: compounds 2, 1 and 3 (each within the scatter of the next).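

In this assay the swap to 2,4-dimethoxyphenyl in place of 2,5-dimethoxyphenyl on a double-bonded chain carbon bound to a double-bonded chain carbon gives a step within the scatter (a 1.0-fold higher number from compound 1 to compound 3 (0.01 log units; within the scatter)). Among these compounds, this is the first single-place comparison at this position, and on these two compounds the two dimethoxyphenyl patterns cannot be told apart. Nothing at hand offers an explanation for this result. On these data alone, whether the position accepts a different group, such as a phenyl ring carrying an amine or a carboxylic acid, remains open.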